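The source may report more compounds than this note shows. Statements on the series, on what has been measured and on what is new or still open speak of the compounds shown alone.

Measured compounds:
- compound 1 `O=c1ccoc2cc(OCc3cn(Cc4ccccc4)nn3)ccc12` — > 100000 nM, a limit of the assay, not a number.
- compound 2 `O=c1ccoc2cc(OCc3cn(Cc4ccc(Cl)cc4)nn3)ccc12` — > 100000 nM, likewise a limit.
- compound 3 `O=c1ccoc2cc(OCc3cn(Cc4ccccc4F)nn3)ccc12` — > 100000 nM, likewise a limit.

In a functional assay on SGC-7901 cells (Homo sapiens) for cytotoxicity, read by MTT assay, with a stated time of 48 h (a higher number here means a weaker inhibitor, a lower number a stronger inhibitor), compound 1 stands only at the limit, with no number of its own. Every value in the series sits at the limit of > 100000 nM in this assay, at which 3 of the 3 values shown sit, so the steps a step that the two limits leave unreadable from compound 1 to compound 2, a step that the two limits leave unreadable from compound 1 to compound 3 and a step that the two limits leave unreadable from compound 2 to compound 3 cannot be read in either direction; they say nothing about whether substitution on the benzyl ring helps or hurts.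

Compound 4 `N#Cc1ccc(Cn2cc(COc3ccc4c(=O)ccoc4c3)nn2)cc1` differs from compound 1 by cyano in place of hydrogen on an aromatic carbon. For the measured compounds named here, the steps that bear on this change are the two other substitutions on the same ring, from compound 1 to compound 2 and from compound 1 to compound 3, and both are unreadable. No step beyond the scatter can therefore be expected in this assay in any direction; the expectation is that compound 4 stays at the limit, as a number no higher from compound 1 to compound 4 (the limit leaves the size open) expresses. Compound 4 is estimated at 100000 nM, with a range of 30000 nM to 300000 nM.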

Compound 4, half-maximal inhibitory concentration: > 100000 nM
Compound 4: only a limit was reported (the forecaster's own chance of this, stated with the estimate: 80%); the middle value sits exactly at the limit.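

Compound 4 also gives only a limit in this assay, so its steps to compound 1, compound 2 and compound 3 cannot be read: the limit of > 100000 nM in this assay, at which 4 of the 4 values shown sit.

The compounds shown leave open whether any substitution on the benzyl ring shifts cytotoxicity at all, and in which direction.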